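The compounds below may be only part of what the source reports. "The series", "measured", "known", "first", "only" and "open" are said of these compounds alone.

Three compounds share one core and differ only in the group attached to an aromatic carbon of it. In an ADME assay on HeLa cells (Homo sapiens) for cytotoxicity, read by sulforhodamine B assay, with a stated time of 48 h, tested at 10 uM (a higher number here means more inhibition at the concentration tested (going by the name of the read-out), a lower number less inhibition), compound 1 `COc1nc2ccc(Br)cc2cc1C(c1ccccc1)n1cc(-c2ccccc2)nn1`, carrying a phenyl group there, gives 13.9%. Compound 2 `CCCCCCCCc1cn(C(c2ccccc2)c2cc3cc(Br)ccc3nc2OC)nn1`, with octyl in its place, gives 0.1%. Compound 3 `COc1nc2ccc(Br)cc2cc1C(c1ccccc1)n1cc(CCCO)nn1`, with 3-hydroxypropyl, gives 11.3%. Compound 3 thus holds the second highest of the three numbers: its value lies within the scatter of compound 1, while a number 11.2 percentage points higher from compound 2 to compound 3 (beyond the scatter) is a modest step beyond it. Compound 4 `COc1nc2ccc(Br)cc2cc1C(c1ccccc1)n1cc(-c2cccc(F)c2)nn1` is not yet measured; it differs from compound 3 in one place: 3-fluorophenyl in place of 3-hydroxypropyl on an aromatic carbon. The step that bears most directly on this change is a number 2.6 percentage points lower from compound 1 to compound 3 (within the scatter), which shows that swapping phenyl for 3-hydroxypropyl moved the number only within the scatter. Within the data shown here, compound 4 carries a 3-fluorophenyl group, which resembles phenyl far more closely than it resembles octyl, and the one marked change among the measured compounds, a number 13.8 percentage points lower from compound 1 to compound 2 (beyond the scatter), came with octyl. Compound 4 is therefore expected to show only a small step, a number 2.7 percentage points higher from compound 3 to compound 4 (within the scatter), within the scatter. The estimate for compound 4 is 14%, with a range from 4% to 25%.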

Compound 4, a percentage reported as inhibition, at one concentration (the size of the read-out at that concentration, not a potency): 9.04%
Compound 4: the middle estimate sits 5 percentage points above what was measured, and the stated range covers the measured number.
By their numbers in this assay, from the lowest: compounds 2, 4, 3 and 1 (each within the scatter of the next, the first and the last beyond it).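

In this assay the change at this carbon of the five-membered ring gives a number 2.3 percentage points lower from compound 3 to compound 4 (within the scatter): a chain with a hydrogen-bond donor and acceptor gives way to a six-membered aromatic ring with neither, and the two compounds cannot be told apart. Adding a fluoro group to the phenyl ring gives a number 4.9 percentage points lower from compound 1 to compound 4 (within the scatter), and the comparison with the octyl compound gives a number 8.9 percentage points higher from compound 2 to compound 4 (within the scatter), so compound 2, which stands apart from compound 1 and compound 3, does not stand apart from compound 4, and the octyl group is less clearly set off from the others than the earlier numbers suggested. Nothing measured here offers a reason for any of these numbers.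

Still open, on these data alone, is whether an amine or a carboxylic acid in place of the hydroxy of the 3-hydroxypropyl group, or a methoxy or chloro group in place of the fluoro on the ring, would move the number beyond the scatter. As far as these compounds go, each number comes from a single concentration and is not a potency, so how these compounds compare across a range of concentrations also stays open.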